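The compounds below may be only part of what the source reports. "The series", "measured", "known", "first", "only" and "open" are said of these compounds alone.

Measured so far in an ADME assay on HeLa Rh cells (Homo sapiens) for cytotoxicity, read by microscopy; on this read-out higher numbers stand for lower toxicity in this test and lower numbers for higher toxicity in this test: compound 1 `COc1cc(CC(O)c2ccc(-c3ccc(CO)cc3)cc2)c([N+](=O)[O-])cc1OC`, compound 2 `COc1cc(CC(O)c2ccc(-c3ccc(F)cc3)cc2)c([N+](=O)[O-])cc1OC` with 4500 nM, and compound 3 `COc1cc(CC(O)c2ccc(-c3cccc(F)c3)cc2)c([N+](=O)[O-])cc1OC` with 7400 nM. For compound 1 only a limit of the assay is known, > 244000 nM.

Of the two numbers shown, compound 3 stands highest, the nearest being compound 2, with the step of a 1.6-fold higher number from compound 2 to compound 3 (0.22 log units; within the scatter) lying within the scatter. Compound 4 `COc1cc(CC(O)c2ccc(-c3ccccc3C#N)cc2)c([N+](=O)[O-])cc1OC` differs from compound 3 by 2-cyanophenyl in place of 3-fluorophenyl on an aromatic carbon. The steps of an at least 54-fold lower number from compound 1 to compound 2 (1.73 log units; beyond the scatter) and an at least 32-fold lower number from compound 1 to compound 3 (1.51 log units; beyond the scatter) were large, each exchanging a hydroxymethyl for a fluoro, whereas the step of a 1.6-fold higher number from compound 2 to compound 3 (0.22 log units; within the scatter), which changed only the fluorophenyl, stayed within the scatter. For the measured compounds named here, no measured step exchanges a fluoro for a nitrile, so in this assay the expected step of a 1.6-fold higher number from compound 3 to compound 4 (0.21 log units; within the scatter) is modest and upward. Compound 4 is therefore estimated at 12000 nM, between 3500 nM and 45000 nM.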

Compound 4, half-maximal cytotoxic concentration: 9300 nM
Estimate against measurement, compound 4: 1.3-fold (0.11 log units) above; the measured number falls inside the stated range.
By their numbers in this assay, from the lowest: compounds 2, 3 and 4 (each within the scatter of the next, the first and the last beyond it). At a limit, above all of these: compound 1.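

Exchanging 3-fluorophenyl for 2-cyanophenyl at this place, para to a large group, stays within the scatter, a 1.3-fold higher number from compound 3 to compound 4 (0.10 log units; within the scatter), so a nitrile serves here without fluorine on the ring. The step of a 2.1-fold higher number from compound 2 to compound 4 (0.32 log units; beyond the scatter) is modest and lies just beyond the scatter. The step of an at least 26-fold lower number from compound 1 to compound 4 (1.41 log units; beyond the scatter) is large, as with both fluorophenyl rings, leaving 4-(hydroxymethyl)phenyl alone apart, and it rests on a limit: the limit of > 244000 nM in this assay, at which 1 of the 4 values shown sits.

Open, as far as these compounds go, is whether an aminomethyl group or a carboxylic acid on that ring would also give so high a number. Also open, from the compounds shown here alone, is how a nitrile would read at the other ring places.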